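The source may report more compounds than this note shows. Statements on the series, on what has been measured and on what is new or still open speak of the compounds shown alone.

Values in a functional assay on MCF7 cells (Homo sapiens) for antiproliferative activity, read by MTT assay, with a stated time of 48 h (a lower number here means a stronger inhibitor, a higher number a weaker inhibitor), so far

- compound 1 (`COc1cccc(C(=O)Nc2nnc(/C=C/c3cc(OC)c(OC)c(OC)c3Br)s2)c1`) gives 170 nM in this assay
- compound 2 (`COc1ccc(C(=O)Nc2nnc(/C=C/c3cc(OC)c(OC)c(OC)c3Br)s2)cc1`) gives 560 nM in this assay
- compound 3 (`COc1cc(/C=C/c2nnc(NC(=O)c3ccc(Br)cc3)s2)c(Br)c(OC)c1OC`) gives 320 nM in this assay

Compound 3 cannot be told apart from either of the other two compounds, since the steps of a 1.9-fold higher number from compound 1 to compound 3 (0.27 log units; within the scatter) and a 1.8-fold lower number from compound 2 to compound 3 (0.24 log units; within the scatter) both lie within the scatter. Going by the values given here, only the step of a 3.3-fold higher number from compound 1 to compound 2 (0.52 log units; beyond the scatter) goes beyond it, and that step moves the methoxy group, from 3-methoxyphenyl to 4-methoxyphenyl.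

The change from compound 3 to compound 4 (`COc1cc(/C=C/c2nnc(NC(=O)c3ccc(Cl)cc3)s2)c(Br)c(OC)c1OC`) is chloro in place of bromo on an aromatic carbon and amounts to chloro in place of bromo on an aromatic carbon, para to a large group. Among the compounds with values here, no measured pair makes this exchange. The closest evidence is bromo in place of methoxy on an aromatic carbon, the step of a 1.8-fold lower number from compound 2 to compound 3 (0.24 log units; within the scatter) that stays within the scatter. On that single comparison, no step beyond the scatter is expected in this assay and no direction is favoured. The estimated step is no change at the digits printed from compound 3 to compound 4 (within the scatter) and it is not expected to leave the scatter. Compound 4 is estimated at 320 nM with an expected range from 140 nM to 720 nM in this assay.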

Compound 4, half-maximal inhibitory concentration: 280 nM
Estimate against measurement, compound 4: 1.1-fold (0.06 log units) above, within the range that was stated.
By their numbers in this assay, from the lowest: compounds 1, 4, 3 and 2 (each within the scatter of the next, the first and the last beyond it).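

In this assay, going by these compounds alone, chloro in place of bromo, para to a large group, gives the first direct reading of one halogen against another at this position: a 1.1-fold lower number from compound 3 to compound 4 (0.06 log units; within the scatter), so the two halogens cannot be told apart here. Within the data shown here, the comparisons with the methoxy-bearing compounds also stay inside the scatter, with a 2.0-fold lower number from compound 2 to compound 4 (0.30 log units; within the scatter) and a 1.6-fold higher number from compound 1 to compound 4 (0.22 log units; within the scatter), so the 4-chlorophenyl amide cannot be separated from either 3-methoxyphenyl or 4-methoxyphenyl on this read-out, and the only step beyond the scatter remains a 3.3-fold higher number from compound 1 to compound 2 (0.52 log units; beyond the scatter). No measurement is available that bears on why these groups read alike.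

The compounds shown leave open whether a group of another kind at this position, such as an amine, a carboxylic acid or a nitrile, would give a step beyond the scatter, since so far only bromo, chloro and methoxy have been compared there. They also leave open whether a halogen responds to a change of place on this ring as the methoxy group does in this assay.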